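The source may report more compounds than this note shows. Statements on the series, on what has been measured and on what is new or still open speak of the compounds shown alone.

The three measured compounds share one core. Compound 1 `N#CC1CN1C(=O)Nc1ccc(Cl)c(Cl)c1` gives 4400 nM in a functional assay on MCF7 cells (Homo sapiens) for inhibition; a lower number here means a stronger inhibitor, a higher number a weaker inhibitor. Compound 2 `CCOC(=O)c1ccc(NC(=O)N2CC2C#N)cc1` gives 3300 nM in this assay, and compound 3 `N#CC1CN1C(=O)Nc1ccc([N+](=O)[O-])cc1` gives 3000 nM; all three sit inside the scatter of one another, so none stands apart. For the measured compounds named here, the one measured step, a 1.1-fold lower number from compound 2 to compound 3 (0.04 log units; within the scatter), swapped the group on the aromatic carbon and left the number in place. Compound 4 `N#CC1CN1C(=O)Nc1ccc(C(F)(F)F)cc1` carries trifluoromethyl in place of nitro on an aromatic carbon. Going by the values given here, only that step bears on this change, and it lay within the scatter, so compound 4 is expected to show no step beyond the scatter, a 1.2-fold higher number from compound 3 to compound 4 (0.07 log units; within the scatter). Compound 4 is therefore estimated at 3500 nM, with a range from 1500 nM to 8000 nM.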

Compound 4, half-maximal inhibitory concentration: 1300 nM
Compound 4: the middle estimate sits 2.7-fold (0.43 log units) above what was measured; measured number below the stated range.
By their numbers in this assay, from the lowest: compound 4; then compounds 3, 2 and 1 (each within the scatter of the next).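

Trifluoromethyl is the first group on this aromatic carbon to shift the number in this assay beyond the scatter (a 2.3-fold lower number from compound 3 to compound 4 (0.36 log units; beyond the scatter); a 2.5-fold lower number from compound 2 to compound 4 (0.40 log units; beyond the scatter)). The position therefore responds to what it carries, even though nitro and ethoxycarbonyl gave no difference there, but the shift is only modest. Nothing shown explains why this group gives the lower number. On these data alone, whether an amine or a carboxylic acid on this carbon would give a lower or higher number remains open. So does whether the trifluoromethyl step holds with another group in place of the nitrile.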